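Chloro in Place of Benzyloxy on the Shared Core

The source may hold more compounds than are shown below. What is called first, only, known or untested is meant among the compounds shown, and "the series" means these compounds.

In a functional assay on MCF7 cells (Homo sapiens) for antiproliferative activity, read by MTT assay, with a stated time of 24 h (on this read-out lower numbers stand for stronger inhibition of growth and higher numbers for weaker inhibition of growth), compound 1 (`c1ccc(COc2ccc(C3CC(c4ccc5c(c4)OCCO5)=NN3c3ccccc3)cc2)cc1`) gives 23600 nM and compound 2 (`c1ccc(COc2cccc(C3CC(c4ccc5c(c4)OCCO5)=NN3c3ccccc3)c2)cc1`) gives 14800 nM so the two numbers lie within the scatter of each other and cannot be ranked. Compound 2 therefore stands level with compound 1 on the evidence so far.

The next compound to be tested is compound 3 (`Clc1cccc(C2CC(c3ccc4c(c3)OCCO4)=NN2c2ccccc2)c1`), which keeps the shared core of compound 2 but carries chloro in place of benzyloxy on an aromatic carbon, meta to a large group (chloro in place of benzyloxy on an aromatic carbon). Among the measured compounds shown here, no measured pair shows what this exchange does, and neither tested compound carries chloro. The expectation can lean only on the close agreement of the two known values, so no step beyond the scatter is expected in this assay for this exchange, though the uncertainty is wide. The expected change is a 1.2-fold higher number from compound 2 to compound 3 (0.09 log units; within the scatter) and this estimated step stays within the scatter. In this assay compound 3 is estimated at 18000 nM with 7000 nM to 45000 nM as its expected range.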

Compound 3, concentration for 50% growth inhibition: 55900 nM
Compound 3: middle estimate off by 3.1-fold (0.49 log units), on the low side; the measured number lies above the stated range.
By their numbers in this assay, from the lowest: compounds 2 and 1 (each within the scatter of the next); then compound 3.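

In this assay, chloro in place of benzyloxy on this aromatic carbon gives a step beyond the scatter, a 3.8-fold higher number from compound 2 to compound 3 (0.58 log units; beyond the scatter), and so weaker inhibition of growth. Compound 1 and compound 2 both carry benzyloxy and cannot be ranked against each other, so they gave no sign of how much the group at this place matters; this exchange shows that the number does respond to what sits there, and that benzyloxy cannot be swapped for chloro here without a loss. Nothing measured on these compounds accounts for the size of this step.

The exchange removes the ether oxygen and the aromatic ring of benzyloxy and brings in chloro all at once, so the compounds shown leave open which of these changes goes with the higher number. A methoxy group or a phenyl group at the same place would help to separate them, and fluoro or a longer chain ending in an amine would show whether the trend holds beyond this single pair.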